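From ethoxy to pyridin-4-yl on a weakly active compound

A few compounds are considered here, and "the series" means these few. Any claim that something is new, unique, unknown or untested is made for them only; others in the source may bear on it.

Compound 1 `CCO[C@H]1C[C@@H](c2coc3ccccc3c2=O)N(c2ccccc2)O1`: > 60000 nM (a limit)
Compound 2 `CCO[C@H]1C[C@@H](c2coc3ccc(F)cc3c2=O)N(c2ccccc2)O1`: 31700 nM

In a functional assay on PC-3 cells (Homo sapiens) for inhibition, read by sulforhodamine B assay, with a stated time of 48 h (on this read-out lower numbers stand for stronger inhibition and higher numbers for weaker inhibition), compound 1 reads > 60000 nM, which is a limit of the assay and not a number. Compound 3 `O=c1c([C@@H]2C[C@H](c3ccncc3)ON2c2ccccc2)coc2ccccc12` differs from compound 1 in one place, with pyridin-4-yl in place of ethoxy on a saturated ring carbon. Within the data shown here, the only measured step is an at least 1.8-fold lower number from compound 1 to compound 2 (0.27 log units; that floor lies within the scatter), made by fluoro in place of hydrogen on an aromatic carbon. That step stays within the scatter and lies at a different place, so it says little about this swap. No measurement covers a change at the ethoxy place. Among the measured compounds shown here, with compound 2 at 31700 nM as the only true number in this assay, a weak result is expected again, with a small move towards lower numbers or none beyond the scatter. That expectation amounts to an estimated at least 1.5-fold lower number from compound 1 to compound 3 (0.19 log units; that floor lies within the scatter), and the assay may again report only a limit. For compound 3 the estimated value is 38000 nM, with an expected range from 14000 nM to 60000 nM.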

Compound 3, half-maximal inhibitory concentration: 46000 nM
Compound 3: middle estimate off by 1.2-fold (0.08 log units), on the low side, within the range that was stated.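

In this assay, placing pyridin-4-yl instead of ethoxy on the saturated ring carbon next to the ring oxygen gives an at least 1.3-fold lower number from compound 1 to compound 3 (0.11 log units; that floor lies within the scatter). Among these compounds, this is the first reading of a change at this place, since the fluoro step acted elsewhere on the molecule, and it shows that replacing a small open chain with a six-membered aromatic ring still leaves compound 3 weak, at 46000 nM. Compound 1 has only a limit and not a number, so this step has a known floor but no known size, and the change cannot be called a true gain: the limit of > 60000 nM in this assay, at which 1 of the 3 values shown sits.

The compounds shown leave open whether any group at this ring carbon can move the number clearly beyond the scatter, such as a primary amine, a carboxylic acid or a longer chain like butoxy. They also leave open whether pyridin-4-yl at this place and the fluoro of compound 2, carried together on the shared core, would give a lower number than either change alone.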